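The compounds below may be only part of what the source reports. "The series", "measured", "known", "first", "only" and "open" are said of these compounds alone.

Measured so far, all in a functional assay on cells (Platelet, Homo sapiens) for inhibition; a lower number here means a stronger inhibitor, a higher number a weaker inhibitor:

compound 1 `CCOC(=O)c1cccc(-c2n[nH]c3ccccc23)c1`: 5650 nM
compound 2 `CCOC(=O)c1ccc(-c2nn(C)c3ccccc23)cc1`: 270 nM
compound 3 `CCOC(=O)c1ccc(-c2nn(Cc3ccccc3F)c3ccccc23)cc1`: 110 nM

Compound 3 gives the lowest of the three numbers in this assay. Its nearest neighbour is compound 2, and the step of a 2.5-fold lower number from compound 2 to compound 3 (0.39 log units; beyond the scatter) is modest but lies beyond the usual scatter. For the measured compounds named here, compound 1 is furthest away: its value of 5650 nM sits far above that of compound 3, and the two differ in more than one place, so no single step between them is counted.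

Compound 4 `CCOC(=O)c1ccc(-c2nn(Cc3cccc(OC)c3)c3ccccc23)cc1` differs from compound 3 in one place: 3-methoxyphenyl in place of 2-fluorophenyl on a saturated chain carbon bound to an aromatic nitrogen. Going by the values given here, the only measured step that touches this position is a 2.5-fold lower number from compound 2 to compound 3 (0.39 log units; beyond the scatter), which replaced a hydrogen by 2-fluorophenyl on that chain carbon. Among the compounds with values here, no measured pair compares one substituted phenyl with another at this position, so nothing in the data says whether 3-methoxyphenyl should read higher or lower than 2-fluorophenyl. The expectation is therefore a step of no more than the scatter, in no preferred direction, a 1.2-fold higher number from compound 3 to compound 4 (0.07 log units; within the scatter). Compound 4 is estimated at 130 nM, with a range from 50 nM to 350 nM.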

Compound 4, half-maximal inhibitory concentration: 260 nM
Estimate against measurement, compound 4: 2.0-fold (0.30 log units) below, and the stated range covers the measured number.
By their numbers in this assay, from the lowest: compound 3; then compounds 4 and 2 (each within the scatter of the next); then compound 1.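

In this assay, the group on this chain carbon matters in its detail, not merely through the presence of a ring: replacing 2-fluorophenyl with 3-methoxyphenyl gives a 2.4-fold higher number from compound 3 to compound 4 (0.37 log units; beyond the scatter) and takes back the gain that compound 3 had shown. Set against the hydrogen of compound 2, the 3-methoxyphenyl group gives a 1.0-fold lower number from compound 2 to compound 4 (0.02 log units; within the scatter) and so brings no gain that can be told from the scatter, even though it adds a whole ring with its substituent. No evidence at hand accounts for the gap between these two groups.

The two rings differ both in their substituent and in where it sits, so the compounds shown cannot tell whether the fluorine, the methoxy or the placement carries the difference. Also open, going by these compounds, is how a benzyl with no substituent on its ring would read, and whether an amine or a longer chain at this place would give a number lower than that of compound 3.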